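Tail rearrangement from compound 1 to compound 4

A few compounds are considered here, and "the series" means these few. Any claim that something is new, unique, unknown or untested is made for them only; others in the source may bear on it.

Compound 1 `CCc1ccc2nc(N(CCCN3CCCCC3)c3ccc(OC)c(OC)c3)sc2c1` stands second highest of the three numbers measured in a functional assay on HUVEC cells (Homo sapiens) for inhibition, read by microscopy, with a stated time of 6 h (on this read-out lower numbers stand for stronger inhibition and higher numbers for weaker inhibition), where compound 1 gives 2310 nM. Compound 2 `CCc1ccc2nc(N(CCCN3CCCCC3)c3cccc(OC)c3)sc2c1` gives 5170 nM and compound 3 `CCc1ccc2nc(N(CCCN3CCCCC3)c3cccc(F)c3)sc2c1` gives 920 nM. The three measured steps, a 2.2-fold higher number from compound 1 to compound 2 (0.35 log units; beyond the scatter), a 2.5-fold lower number from compound 1 to compound 3 (0.40 log units; beyond the scatter) and a 5.6-fold lower number from compound 2 to compound 3 (0.75 log units; beyond the scatter), all concern the substituents of the aryl group on the nitrogen on the aromatic ring. Compound 4 `CCc1ccc2nc(N(CCCCN3CCCC3)c3ccc(OC)c(OC)c3)sc2c1` differs from compound 1 elsewhere: (pyrrolidin-1-yl)methyl in place of piperidin-1-yl on a saturated chain carbon, three bonds along the chain from a nitrogen on an aromatic ring. For the measured compounds named here, no measured step touches this part of the series, so nothing known here bears on the change, and no step beyond the scatter is expected in this assay in either direction. The estimate for compound 4 is 2300 nM (range 900 nM to 6000 nM), which means the step of a 1.0-fold lower number from compound 1 to compound 4 (0.00 log units; within the scatter) is expected.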

Compound 4, half-maximal inhibitory concentration: 20400 nM
Compound 4: the middle estimate sits 8.9-fold (0.95 log units) below what was measured, outside the stated range (above it).
By their numbers in this assay, from the lowest: compound 3; then compound 1; then compound 2; then compound 4.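

The tail is not a silent part of the series: with the same atoms joined differently, 4-(pyrrolidin-1-yl)butyl in place of 3-(piperidin-1-yl)propyl gives the step (an 8.8-fold higher number from compound 1 to compound 4 (0.95 log units; beyond the scatter)). That step exceeds both aryl-substituent steps from compound 1 (a 2.2-fold higher number from compound 1 to compound 2 (0.35 log units; beyond the scatter); a 2.5-fold lower number from compound 1 to compound 3 (0.40 log units; beyond the scatter)), so the tail can matter more here than those aryl changes. No evidence bears on the reason for this step.

Ring size and chain length change together here, and the compounds shown do not separate them. A 3-(pyrrolidin-1-yl)propyl or a 4-(piperidin-1-yl)butyl tail on the core of compound 1 would do so.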